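Quinolinyl Amide in Place of a Cinnamoyl Chain

The source may report more compounds than this note shows. Statements on the series, on what has been measured and on what is new or still open speak of the compounds shown alone.

Compound 1 `CCCN(CC[C@H]1CC[C@H](NC(=O)/C=C/c2ccc(F)cc2)CC1)[C@H]1CCc2nc(N)sc2C1`: 1 nM
Compound 2 `CCCN(CC[C@H]1CC[C@H](NC(=O)/C=C/c2ccc(Cl)cc2)CC1)[C@H]1CCc2nc(N)sc2C1`: 2.5 nM
Compound 3 `CCCN(CC[C@H]1CC[C@H](NC(=O)/C=C/c2cccc(Cl)c2)CC1)[C@H]1CCc2nc(N)sc2C1`: 1.2 nM

Three compounds sharing one core were measured in an assay on brain for displacement of a labelled ligand from D(3) dopamine receptor (Rattus norvegicus); a lower number here means a stronger inhibitor, a higher number a weaker inhibitor. Compound 1 gives the lowest number of the three; compound 3 sits within the scatter of it, and only compound 2 lies beyond, with a 2.5-fold higher number from compound 1 to compound 2 (0.40 log units; beyond the scatter). The change from compound 2 to compound 3 was also modest: a 2.1-fold lower number from compound 2 to compound 3 (0.32 log units; beyond the scatter). Compound 1 is thus the natural reference point.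

Compound 4 `CCCN(CC[C@H]1CC[C@H](NC(=O)c2cccc3ncccc23)CC1)[C@H]1CCc2nc(N)sc2C1` departs from compound 1 in a larger way than any measured step: quinolin-5-yl in place of 2-(4-fluorophenyl)ethenyl on a carbonyl carbon. The measured steps touched only the substituent on the aromatic ring or its position, and none removed the double bond outside the aromatic ring or introduced a second fused ring with a hydrogen-bond acceptor. They therefore bear only loosely on this step; what they do show is that the amide-linked aromatic portion tolerates small variation without large shifts in this assay. Compound 4 is expected to remain a strong inhibitor in this assay, with a step of a 3.0-fold higher number from compound 1 to compound 4 (0.48 log units; beyond the scatter) expected, a small loss that may not exceed the scatter. The estimate for compound 4 is 3 nM, in the range 0.8 nM to 12 nM.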

Compound 4, inhibition constant: 1.6 nM
Estimate against measurement, compound 4: 1.9-fold (0.27 log units) above; measured number inside the range.
By their numbers in this assay, from the lowest: compounds 1, 3, 4 and 2 (each within the scatter of the next, the first and the last beyond it).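

In this assay, putting quinolin-5-yl in place of the whole 2-(4-fluorophenyl)ethenyl group on the carbonyl carbon left the number within the scatter (a 1.6-fold higher number from compound 1 to compound 4 (0.20 log units; within the scatter)), and the same holds against the two chloro compounds (a 1.3-fold higher number from compound 3 to compound 4 (0.12 log units; within the scatter); a 1.6-fold lower number from compound 2 to compound 4 (0.19 log units; within the scatter)). The earlier compounds shown here had varied only the substituent on the aromatic ring or its position, whereas this result shows that the place on the carbonyl carbon also accepts a group with no double bond outside the aromatic rings, with a second aromatic ring and a hydrogen-bond acceptor, without a step beyond the scatter to any of the three earlier compounds. Nothing available accounts for how closely the two kinds of group read in this assay.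

The compounds shown leave open whether the ring nitrogen of quinolin-5-yl plays any part, which an all-carbon naphthalen-1-yl group on the same carbonyl carbon would test. They also leave open how quinolin-3-yl, a plain phenyl or a longer chain ending in an aromatic ring would read at this place in this assay.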